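The source may hold more compounds than are shown below. What is called first, only, known or untested is meant among the compounds shown, and "the series" means these compounds.

Measured compounds:
Compound 1 `CCCCN(c1nc2c(NC(C)=O)cccc2o1)[C@H](C)c1ccc(-c2ccccc2-c2nnn[nH]2)cc1`: 0.00102
Compound 2 `CCCCN(c1nc2c(C(=O)N(C)C)cccc2o1)[C@H](C)c1ccc(-c2ccccc2-c2nnn[nH]2)cc1`: 0.00411
Compound 3 `CCCCN(c1nc2c(C(=O)O)cccc2o1)[C@H](C)c1ccc(-c2ccccc2-c2nnn[nH]2)cc1`: 0.000285

These three share one core and differ only in the group on an aromatic carbon of that core. In an ADME assay on the whole organism (plasma, Macaca fascicularis) for protein binding, read by LC-MS, using equilibrium dialysis and cassette dosing, with a stated time of 24 h, at a dose of 1 mg/kg by the oral route (a lower number here means a smaller unbound share, a higher number a larger unbound share of the compound), compound 3 gives the lowest of the three numbers, so the smallest unbound share. Its nearest neighbour is compound 1, a step of a 3.6-fold lower number from compound 1 to compound 3 (0.55 log units; beyond the scatter) that lies beyond the scatter; its furthest is compound 2, a step of a 14-fold lower number from compound 2 to compound 3 (1.16 log units; beyond the scatter) that is large.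

Compound 4 `CCCCN(c1nc2c(-c3ccccn3)cccc2o1)[C@H](C)c1ccc(-c2ccccc2-c2nnn[nH]2)cc1` is not yet measured in this assay. It differs from compound 3 as follows: pyridin-2-yl in place of carboxy on an aromatic carbon. Among the compounds with values here, no measured pair shows pyridin-2-yl entering, so the expectation rests on what leaves. Both steps into compound 3, namely a 3.6-fold lower number from compound 1 to compound 3 (0.55 log units; beyond the scatter) and a 14-fold lower number from compound 2 to compound 3 (1.16 log units; beyond the scatter), show that carboxy on this aromatic carbon gave the smallest unbound share of the set, and the change from dimethylamino to hydroxy on the carbonyl carbon was the largest step. Taking carboxy away again is therefore expected to move the number upward, by a step beyond the scatter, with compounds 1 and 2 as the nearest guide. For compound 4 the expected step is an 11-fold higher number from compound 3 to compound 4 (1.02 log units; beyond the scatter). The estimate for compound 4 in this assay is 0.003, within a range from 0.0008 to 0.012.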

Compound 4, unbound fraction: 0.00129
The estimate for compound 4 lay 2.3-fold (0.37 log units) above the measured number; measured number inside the range.
By their numbers in this assay, from the lowest: compound 3; then compounds 1 and 4 (each within the scatter of the next); then compound 2.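

In this assay, an aromatic ring on this aromatic carbon, with 6 heavy atoms where carboxy has 3, keeps the number inside the span set by the three earlier groups: the change brings a 4.5-fold higher number from compound 3 to compound 4 (0.66 log units; beyond the scatter), yet the ring also stands at a 3.2-fold lower number from compound 2 to compound 4 (0.50 log units; beyond the scatter). Set against acetamido, the ring gives a 1.3-fold higher number from compound 1 to compound 4 (0.10 log units; within the scatter), so these two groups cannot be told apart here, even though acetamido holds a carbonyl and pyridin-2-yl does not. A carbonyl at this place is therefore not needed for an unbound share at this level, and the smallest share in the set remains with the carboxy group. Nothing available here explains why these groups shift the unbound share.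

The compounds shown leave open whether the ring nitrogen of pyridin-2-yl plays any part, which a plain phenyl ring or pyridin-3-yl on the same carbon could help to test. They also leave open how an amine such as aminomethyl, or a longer chain, would compare at this place.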